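Hydroxy on the four-membered ring of compound 1

A few compounds are considered here, and "the series" means these few. Any claim that something is new, unique, unknown or untested is made for them only; others in the source may bear on it.

Compound 1: `O=C(O)c1cccc([C@H]2C[C@@H](c3ccc(OCc4c(-c5c(Cl)cccc5Cl)noc4C4CC4)cc3Cl)C2)c1`, 77 nM
Compound 2: `O=C(O)c1cccc([C@H]2C[C@@H]2c2ccc(OCc3c(-c4c(Cl)cccc4Cl)noc3C3CC3)cc2Cl)c1`, 219 nM

In an assay on isolated protein for agonist activity at Bile acid receptor (Homo sapiens), read by FRET (a higher number here means that more compound is needed for the effect, a lower number that less compound is needed), compound 1 gives 77 nM, the lower of the two numbers measured; compound 2 gives 219 nM, a gap beyond the scatter. Compound 3 is `O=C(O)c1cccc([C@H]2C[C@](O)(c3ccc(OCc4c(-c5c(Cl)cccc5Cl)noc4C4CC4)cc3Cl)C2)c1`. It differs from compound 1 by hydroxy in place of hydrogen on a saturated ring carbon. Among the compounds with values here, no step of this kind has been measured here, so the size of the change is open; a modest shift towards a higher number, near the edge of the scatter, is expected. For compound 3 the estimate is 120 nM, with a range of 40 nM to 400 nM, which means an expected step of a 1.6-fold higher number from compound 1 to compound 3 (0.19 log units; within the scatter).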

Compound 3, half-maximal effective concentration: 29 nM
Compound 3: the middle estimate sits 4.1-fold (0.62 log units) above what was measured; measured number below the stated range.
By their numbers in this assay, from the lowest: compound 3; then compound 1; then compound 2.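

In this assay, hydroxy in place of hydrogen on this saturated ring carbon gives a 2.7-fold lower number from compound 1 to compound 3 (0.42 log units; beyond the scatter), a change beyond the scatter. This shows that the carbon of the four-membered ring can carry a hydroxy group, and that the number falls rather than rises when it does. Nothing shown here gives a reason for the step. Going by these compounds, whether a methoxy group, a fluorine atom or an amine on the same carbon would shift the number in the same direction stays open. So does whether the step depends on the hydroxy group's donor hydrogen.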